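Removing the benzoyloxy group from the enone series

The source may hold more compounds than are shown below. What is called first, only, known or untested is meant among the compounds shown, and "the series" means these compounds.

Among the measured compounds shown here, compound 2 `C=C(C/C(=C\c1ccc(OC(=O)c2ccccc2)cc1)C(=O)c1ccc(OC)cc1)C(=O)c1ccc(OC)cc1` is the only member of the series with a numerical result so far: in a functional assay on NB-4 cells (Homo sapiens) for inhibition, read by XTT assay, with a stated time of 48 h (a higher number here means a weaker inhibitor, a lower number a stronger inhibitor), compound 2 gives 6700 nM. Compound 1 `COc1ccc(C(=O)/C(=C/C2CCCCC2)CCOC(C)=O)cc1` is reported in this assay only as a limit, > 100000 nM, and the limit is where one of the two shown values sits (the limit of > 100000 nM in this assay, at which 1 of the 2 values shown sits). Compound 3 `C=C(C/C(=C\c1ccccc1)C(=O)c1ccc(OC)cc1)C(=O)c1ccc(OC)cc1` has not yet been measured. It differs from compound 2 in one place: hydrogen in place of benzoyloxy on an aromatic carbon. For the measured compounds named here, no measured pair shows the effect of such a change, so the size and direction of this step are open. In this assay the expected step is a 1.5-fold higher number from compound 2 to compound 3 (0.17 log units; within the scatter), which would not stand clearly beyond the usual scatter. For compound 3 the estimate in this assay is 10000 nM, with a likely range from 3000 nM to 40000 nM.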

Compound 3, half-maximal inhibitory concentration: 7400 nM
Compound 3: middle estimate off by 1.4-fold (0.13 log units), on the high side; the measured number falls inside the stated range.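

Replacing benzoyloxy with hydrogen on this aromatic carbon, para to a large group, gives a 1.1-fold higher number from compound 2 to compound 3 (0.04 log units; within the scatter) in this assay. Among the compounds shown here, this is the first measured pair, and it shows that the number stays within the scatter when the whole benzoyloxy group leaves this position, so that group is not required for activity at this level in this assay. The data shown give no cause for this result.

Going by these compounds, whether an amine or a carboxylic acid on the same aromatic carbon would also leave the number within the scatter remains open. Compound 1 differs from compound 3 in more than one place, so the compounds shown do not tell which other parts of the structure matter for activity.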